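Fluoro replacing methoxy: from compound 2 to compound 3

The source may hold more compounds than are shown below. What is called first, only, known or untested is meant among the compounds shown, and "the series" means these compounds.

Among the compounds with values here, compound 2 `COc1ccc(-n2c(S)nnc2CSc2nnc(-c3ccccc3)n2-c2ccccc2)cc1` gives 29200 nM in a functional assay on MDA-MB-231 cells (Homo sapiens) for inhibition, read by MTT assay, with a stated time of 48 h (on this read-out lower numbers stand for stronger inhibition and higher numbers for weaker inhibition), the higher of the two numbers so far; compound 1 `Sc1nnc(CSc2nnc(-c3ccccc3)n2-c2ccccc2)n1-c1ccccc1` gives 8570 nM. Compound 3 `Fc1ccc(-n2c(S)nnc2CSc2nnc(-c3ccccc3)n2-c2ccccc2)cc1` differs from compound 2 by fluoro in place of methoxy on an aromatic carbon. Within the data shown here, one measured step bears on this: a 3.4-fold higher number from compound 1 to compound 2 (0.53 log units; beyond the scatter), in which methoxy replaced hydrogen. Fluoro stands nearer to hydrogen than to methoxy by what the difference counts, so a lower number than compound 2 is expected, partly undoing that step. For compound 3 the estimate is 13000 nM, with a range of 5000 nM to 35000 nM, meaning a 2.2-fold lower number from compound 2 to compound 3 (0.35 log units; beyond the scatter).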

Compound 3, half-maximal inhibitory concentration: 26800 nM
Compound 3: the middle estimate sits 2.1-fold (0.31 log units) below what was measured; the range from low to high includes it.
By their numbers in this assay, from the lowest: compound 1; then compounds 3 and 2 (each within the scatter of the next).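

In this assay the swap at this position gives a 1.1-fold lower number from compound 2 to compound 3 (0.04 log units; within the scatter), so the 4-methoxyphenyl and 4-fluorophenyl compounds read alike. Fluoro in place of hydrogen gives a 3.1-fold higher number from compound 1 to compound 3 (0.50 log units; beyond the scatter), so the higher number is not confined to methoxy: both groups on this aromatic carbon, para to a large group, stand above hydrogen. The data at hand offer no reason for this. Going by these compounds, whether an amine, a carboxylic acid or a longer chain here would also raise the number stays open, as does whether any group at this place can give a lower number than compound 1.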